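Adding methoxy to compound 2: what to expect

The compounds below may be only part of what the source reports. "The series", "measured", "known", "first", "only" and "open" are said of these compounds alone.

Measured so far in a functional assay on MIA PaCa-2 cells (Homo sapiens) for cytotoxicity, read by WST assay, with a stated time of 24 h; on this read-out lower numbers stand for stronger inhibition and higher numbers for weaker inhibition:
compound 1 `COc1ccc2[nH]cc(/C=C(\C#N)C(=O)c3c[nH]c4ccccc34)c2c1` gives 21200 nM
compound 2 `N#C/C(=C\c1c[nH]c2ccccc12)C(=O)c1c[nH]c2ccccc12` gives 17900 nM
compound 3 `COc1ccc(-c2[nH]c3ccccc3c2/C=C(\C#N)C(=O)c2c[nH]c3ccccc23)cc1` gives 24000 nM
compound 4 `COc1ccc2c(C(=O)/C(C#N)=C/c3c[nH]c4ccccc34)c[nH]c2c1` has not yet been measured

The three measured numbers sit close together, and compound 2 at 17900 nM lies within the scatter of both others. Compound 4 differs from compound 2 by one change, (methoxy in place of hydrogen on an aromatic carbon), which is methoxy in place of hydrogen on an aromatic carbon.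

Within the data shown here, two measured steps bear on this, and both stay within the scatter. One is a 1.2-fold lower number from compound 1 to compound 2 (0.07 log units; within the scatter), the same kind of change in reverse, made elsewhere on the shared core. The other is a 1.3-fold higher number from compound 2 to compound 3 (0.13 log units; within the scatter), a different group, also placed elsewhere. On that evidence, no step beyond the scatter is expected in this assay, in either direction. Among the measured compounds shown here, no measured compound carries methoxy at this exact place, so the expectation remains uncertain.

The estimate amounts to an expected 1.1-fold higher number from compound 2 to compound 4 (0.03 log units; within the scatter). For compound 4 the estimated value is 19000 nM, with an expected range from 9000 nM to 38000 nM.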

Compound 4, half-maximal inhibitory concentration: 13500 nM
Compound 4: the middle estimate sits 1.4-fold (0.15 log units) above what was measured, and the stated range covers the measured number.
By their numbers in this assay, from the lowest: compounds 4, 2, 1 and 3 (each within the scatter of the next).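

Compound 4 is the only compound shown with methoxy at this place, on an aromatic carbon of a six-membered aromatic ring of carbon only, and in this assay the change amounts to a 1.3-fold lower number from compound 2 to compound 4 (0.12 log units; within the scatter), so this place takes methoxy with no step beyond the scatter. Methoxy now stays within the scatter at two places on the shared core, this one and the one it occupies in compound 1, though two places are too few to call a pattern. No measurement shown speaks to the reason for this outcome.

What the compounds shown leave open is how a different group at this same place, such as an amine, a carboxylic acid or a longer chain, would read in this assay. They also leave open whether methoxy at this place together with methoxy at the place it holds in compound 1 would stay within the scatter of compound 2.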